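This account rests on a few compounds, and the source may have more. Where it says the series, first, only, none or still open, it means among the compounds named here.

Measured in a functional assay on MCF7 cells (Homo sapiens) for cytotoxicity, read by MTT assay, with a stated time of 96 h; a higher number here means a weaker inhibitor, a lower number a stronger inhibitor:
compound 1 `Cn1c(-c2ccccc2)ccc1-c1ccc(C(=N)N)cc1`: 2700 nM
compound 2 `N=C(N)c1ccc(-c2ccc(-c3ccc([N+](=O)[O-])cc3)o2)cc1`: 3200 nM
compound 3 `N=C(N)c1ccc(-c2ccc(-c3cccc([N+](=O)[O-])c3)o2)cc1`: 3000 nM

Compound 2, at 3200 nM, lies within the scatter of both compound 1 and compound 3, so the three numbers form a single band and cannot be ranked.

The next compound is compound 4 `CC(C)(C)c1ccc(-c2ccc(-c3ccc(C(=N)N)cc3)o2)cc1`, which has tert-butyl in place of nitro on an aromatic carbon, para to a large group: tert-butyl in place of nitro on an aromatic carbon. Within the data shown here, no measured pair isolates this exchange, so this assay gives no direct guide to its size or direction. Among the measured compounds shown here, the only guide is the narrow band itself, with compound 1 at 2700 nM and compound 3 at 3000 nM. On that basis, no step beyond the scatter is expected, although the uncertainty is wide in both directions. The estimated step is a 1.2-fold lower number from compound 2 to compound 4 (0.09 log units; within the scatter). For compound 4 the estimated value is 2600 nM, with an expected range of 900 nM to 7000 nM.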

Compound 4, half-maximal inhibitory concentration: 3700 nM
Compound 4: the middle estimate sits 1.4-fold (0.15 log units) below what was measured; low and high end bracket the measured number.
By their numbers in this assay, from the lowest: compounds 1, 3, 2 and 4 (each within the scatter of the next).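

In this assay, tert-butyl in place of nitro on an aromatic carbon, para to a large group, reads as a 1.2-fold higher number from compound 2 to compound 4 (0.06 log units; within the scatter), and so gives no separable difference at this position. The exchange is a wide one in the terms counted: nitro brings nitrogen, oxygen and hydrogen-bond acceptors, while tert-butyl is all carbon with no hydrogen-bond acceptors, yet compound 2 and compound 4 cannot be told apart here. No measured property bears on why these two groups read alike.

As far as these compounds go, whether this position stays as undemanding for an amine or a carboxylic acid remains open, since both would bring a group unlike nitro and tert-butyl. Also open, from the compounds shown here alone, is whether a hydroxyl or a longer chain at the same carbon would leave the band.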